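A few compounds are considered here, and "the series" means these few. Any claim that something is new, unique, unknown or untested is made for them only; others in the source may bear on it.

Compound 1 `CC(=O)N1CC(CC(=O)NO)(NS(=O)(=O)c2ccc(OCc3cc(C)nc4ccccc34)cc2)C1`: 800000 nM
Compound 2 `CCc1cc(COc2ccc(S(=O)(=O)NC3(CC(=O)NO)CN(C(C)=O)C3)cc2)c2ccccc2n1`: 400000 nM
Compound 3 `Cc1cc(COc2ccc(S(=O)(=O)N(C)C3(C(=O)NO)CN(C(=O)C(C)C)C3)cc2)c2ccccc2n1`: 56000000 nM

Of the compounds shown here, three have been measured in a physicochemical assay for solubility, with a stated time of 24 h, tested at 30 mg/mL (on this read-out lower numbers stand for lower solubility and higher numbers for higher solubility), and a fourth, compound 4 `CCN(C1(C(=O)NO)CN(C(=O)C(C)C)C1)S(=O)(=O)c1ccc(OCc2cc(C)nc3ccccc23)cc1`, is still to be measured. Compound 1 and compound 2 share a core and differ only in methyl in place of hydrogen on a saturated chain carbon bound to an aromatic carbon; the step of a 2.0-fold lower number from compound 1 to compound 2 (0.30 log units; within the scatter). Compound 3 gives the highest of the three numbers in this assay; the difference between its core and that of compound 1 is not broken down here. Compound 4 differs from compound 3 by methyl in place of hydrogen on a saturated chain carbon bound to a sulfonamide nitrogen. This is the same kind of change as that from compound 1 to compound 2, though the place is not the same: there the saturated chain carbon is bound to an aromatic carbon, here it is bound to a sulfonamide nitrogen. Because the earlier step of a 2.0-fold lower number from compound 1 to compound 2 (0.30 log units; within the scatter) stayed within the scatter, the step of a 1.6-fold lower number from compound 3 to compound 4 (0.20 log units; within the scatter) is expected to be of similar size. On that basis compound 4 is estimated at 35000000 nM, with a range from 12000000 nM to 90000000 nM.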

Compound 4, solubility: 44000000 nM
Compound 4: middle estimate off by 1.3-fold (0.10 log units), on the low side; the measured number falls inside the stated range.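

In this assay the new step reads a 1.3-fold lower number from compound 3 to compound 4 (0.10 log units; within the scatter), and the earlier step on the other core reads a 2.0-fold lower number from compound 1 to compound 2 (0.30 log units; within the scatter), so methyl in place of hydrogen stays within the scatter in both cases shown. This supports only a limited reading: the two single steps agree, but the place differs along with the core, a saturated chain carbon bound to a sulfonamide nitrogen in one case and one bound to an aromatic carbon in the other, so they do not show that the change at one and the same place would carry from core to core. Nothing shown gives a reason for either step.

The compounds shown leave open whether a longer chain, such as propyl, in place of the ethyl of compound 4 would also stay within the scatter. They also leave open what a chain ending in an amine or a carboxylic acid would do there.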